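From Dichlorophenyl to Difluorophenyl: Expecting Little Change

The source may hold more compounds than are shown below. What is called first, only, known or untested is meant among the compounds shown, and "the series" means these compounds.

Of the compounds shown here, three have so far been measured in a functional assay on CAKI-1 cells (Homo sapiens) for cytotoxicity, read by sulforhodamine B assay, with a stated time of 48 h, tested at 10 uM; on this read-out higher numbers stand for a weaker effect at the one concentration tested and lower numbers for a stronger effect. Compound 1 `COc1cc(-c2cc(/C=C/C(=O)c3ccc(Cl)c(Cl)c3)[nH]n2)cc(OC)c1OC` gives 62%, the highest of the three numbers, which on this read-out means the weakest effect at the single concentration tested. Compound 3 `COc1cc(C(=O)/C=C/c2cc(-c3cc(OC)c(OC)c(OC)c3)n[nH]2)cc(OC)c1OC` gives 4%, and compound 2 `COc1ccc(-c2cc(/C=C/C(=O)c3ccc(N)cc3)[nH]n2)cc1` gives 3%; each of these two stands far below compound 1, well beyond the usual scatter, so both act more strongly than compound 1.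

Compound 4 `COc1cc(-c2cc(/C=C/C(=O)c3ccc(F)c(F)c3)[nH]n2)cc(OC)c1OC` has not yet been measured. It differs from compound 1 in one place: 3,4-difluorophenyl in place of 3,4-dichlorophenyl on a carbonyl carbon. Going by the values given here, no pair of measured compounds shows this particular exchange, so nothing measured tells how large such a step is or which way it points. Because compound 1 gives 62% and the two groups match in every counted respect apart from the halogen, a step from compound 1 to compound 4 of about a number 3 percentage points higher from compound 1 to compound 4 (within the scatter) is expected, that is, none beyond the scatter. Compound 4 is therefore estimated to give 65% in this assay, with a range from 40% to 90%.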

Compound 4, a percentage reported as activity, at one concentration (the size of the read-out at that concentration, not a potency): 12%
Compound 4: the middle estimate sits 53 percentage points above what was measured; measured number outside the range, below it.
By their numbers in this assay, from the lowest: compounds 2, 3 and 4 (each within the scatter of the next); then compound 1.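

In this assay, putting 3,4-difluorophenyl in place of 3,4-dichlorophenyl on a carbonyl carbon gives a number 50 percentage points lower from compound 1 to compound 4 (beyond the scatter), so the effect at the one concentration tested becomes much stronger. Going by these compounds alone, this is the first direct view of this position, and it shows that the halogen alone can change the read-out greatly, even though the two groups have the same heavy-atom count, the same ring, no hydrogen-bond donors or acceptors, and no net charge. No measured evidence here explains why the exchange has this effect.

The compounds shown leave open how a plain phenyl ring or a dibromophenyl group would behave at this position. They also leave open whether the same exchange would give a step of similar size on any core other than that of compound 1.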